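Amine exchange on the chain of compound 3

A few compounds are considered here, and "the series" means these few. Any claim that something is new, unique, unknown or untested is made for them only; others in the source may bear on it.

In a functional assay on BCG823 cells (Homo sapiens) for antiproliferative activity, read by MTT assay, with a stated time of 48 h (a higher number here means a weaker inhibitor, a lower number a stronger inhibitor), compound 1 `O=c1cc(-c2ccccc2)oc2cc(OCc3ccccc3)c(OCCCCN3CCCCC3)c(O)c12` gives 3000 nM and compound 2 `O=c1cc(-c2ccccc2)oc2cc(OCc3ccccc3)c(OCCCN3CCCCC3)c(O)c12` gives 4600 nM while compound 3 `CN1CCN(CCCOc2c(OCc3ccccc3)cc3oc(-c4ccccc4)cc(=O)c3c2O)CC1` gives 4100 nM and so lies within the scatter of both. Compound 4 `CN(C)CCCOc1c(OCc2ccccc2)cc2oc(-c3ccccc3)cc(=O)c2c1O` differs from compound 3 by one change dimethylamino in place of 4-methylpiperazin-1-yl on a saturated chain carbon, three bonds along the chain from an oxygen on an aromatic ring in which dimethylamino stands in place of 4-methylpiperazin-1-yl on a saturated chain carbon. Among the compounds with values here, three steps bear on this: a 1.1-fold lower number from compound 2 to compound 3 (0.05 log units; within the scatter) for the closest amine exchange, then a 1.5-fold higher number from compound 1 to compound 2 (0.19 log units; within the scatter) and a 1.4-fold higher number from compound 1 to compound 3 (0.14 log units; within the scatter) as well, all within the scatter. No open-chain amine has been measured yet. In this assay the expected step of a 1.1-fold higher number from compound 3 to compound 4 (0.04 log units; within the scatter) is therefore none beyond the scatter. Compound 4 is expected at about 4500 nM (estimated range 2200 nM to 9000 nM).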

Compound 4, half-maximal inhibitory concentration: 5500 nM
Beside the measured number, compound 4's estimate is 1.2-fold (0.09 log units) below it; the range from low to high includes it.
By their numbers in this assay, from the lowest: compounds 1, 3, 2 and 4 (each within the scatter of the next).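

Dropping the ring for an open chain does not move the read-out in this assay: dimethylamino gives a 1.3-fold higher number from compound 3 to compound 4 (0.13 log units; within the scatter) and a 1.2-fold higher number from compound 2 to compound 4 (0.08 log units; within the scatter), so neither ring amine is set apart from the open-chain amine. Against (piperidin-1-yl)methyl the step is a 1.8-fold higher number from compound 1 to compound 4 (0.26 log units; within the scatter) and also stays within the scatter, so all the amines shown at this position remain indistinguishable. No measurement in hand accounts for this flat response.

From the compounds shown here alone, whether a carboxylic acid, a morpholine or a primary amine at the chain end would give a step beyond the scatter remains open.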